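A Bromine-to-Trifluoromethyl Swap in a Growth-Inhibition Series

The source may hold more compounds than are shown below. What is called first, only, known or untested is meant among the compounds shown, and "the series" means these compounds.

Of the compounds shown here, three have so far been tested in a functional assay on Huh-7 cells (Homo sapiens) for inhibition, read by sulforhodamine B assay, with a stated time of 72 h; a higher number here means a weaker inhibitor, a lower number a stronger inhibitor. Compound 1 `COc1ccc2cc(C(C)c3nnc4n3N=C(c3ccc(Br)cc3)CS4)ccc2c1` gives 9300 nM. Compound 2 `CC(C)Cc1ccc(C(C)c2nnc3n2N=C(c2ccc(Cl)cc2)CS3)cc1` gives 5700 nM, and compound 3 `CC(c1ccc(-c2ccccc2)c(F)c1)c1n[nH]c(=S)n1N` gives 43100 nM. Compound 1 therefore stands second highest of the three numbers: compound 2 lies within the usual scatter of it, while compound 3 lies beyond the scatter at the higher end. Compound 4 `COc1ccc2cc(C(C)c3nnc4n3N=C(c3ccc(C(F)(F)F)cc3)CS4)ccc2c1` has not yet been measured. It differs from compound 1 in one place: trifluoromethyl in place of bromo on an aromatic carbon. For the measured compounds named here, no step between measured compounds speaks to this particular swap, so in this assay the change is expected to move the number little, if at all, beyond the scatter. The estimate for compound 4 is 8000 nM, within a range from 3000 nM to 25000 nM, which amounts to an expected step of a 1.2-fold lower number from compound 1 to compound 4 (0.07 log units; within the scatter).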

Compound 4, half-maximal inhibitory concentration: 14800 nM
Beside the measured number, compound 4's estimate is 1.9-fold (0.27 log units) below it; the measured number falls inside the stated range.
By their numbers in this assay, from the lowest: compounds 2, 1 and 4 (each within the scatter of the next, the first and the last beyond it); then compound 3.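

In this assay, trifluoromethyl in place of bromo gives a 1.6-fold higher number from compound 1 to compound 4 (0.20 log units; within the scatter). At this position, on an aromatic carbon para to a large group, four heavy atoms can therefore stand in place of one with no difference that repeated measurement could separate. No available information bears on this result.

As far as these compounds go, whether an amine or a carboxylic acid at this position would also leave the number within the scatter remains open. So does whether this swap would give a similar step in compound 2.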